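The source may hold more compounds than are shown below. What is called first, only, known or untested is meant among the compounds shown, and "the series" means these compounds.

Working notes on the series. Among the compounds with values here, in a functional assay on IMR-32 cells (Homo sapiens) for antiproliferative activity, read by MTT assay (a lower number here means a stronger inhibitor, a higher number a weaker inhibitor), compound 1 `CC1(C)CCc2cc(C(=O)/C=C/c3ccc(OCc4cn(-c5ccc(Cl)cc5)nn4)cc3)c(O)cc2O1` gives 92100 nM as its half-maximal inhibitory concentration, and this is the only number so far. Compound 2 `Cc1ccc(-n2cc(COc3ccc(/C=C/C(=O)c4cc5c(cc4O)OC(C)(C)CC5)cc3)nn2)cc1Br` is reported as "not active" (no number reported) in this assay and therefore has no single number, so it cannot be ranked against compound 1 by a measured step.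

The next compound to be measured is compound 3 `CCCCCn1cc(COc2ccc(/C=C/C(=O)c3cc4c(cc3O)OC(C)(C)CC4)cc2)nn1` with the same shared core. The change pentyl in place of 3-bromo-4-methylphenyl on an aromatic nitrogen puts pentyl in place of 3-bromo-4-methylphenyl on an aromatic nitrogen of a five-membered aromatic ring with 3 nitrogen, so a ring leaves and an open chain enters.

Within the data shown here, no measured step involves this position, and compound 2 offers no number to start from. Among the measured compounds shown here, the only anchor is compound 1 at 92100 nM in this weak range. Compound 3 is expected to stay close to that level, with no shift beyond the scatter in either direction, and a report without a number remains possible.

For compound 3 the estimated value is 70000 nM with an expected range from 25000 nM to 200000 nM in this assay for this read-out.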

Compound 3, half-maximal inhibitory concentration: "not active" (no number reported)
The entry for compound 3 holds no number, so the estimate cannot be set against anything.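

In this assay compound 2 and compound 3 both stand without a number, so no step can be read between them. The compounds shown leave open whether pentyl and 3-bromo-4-methylphenyl differ at all on the shared core in this read-out. No evidence on hand bears on this result.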